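Swapping a Flexible Amine Chain for a Diamino Cyclohexyl Ring

The source may report more compounds than this note shows. Statements on the series, on what has been measured and on what is new or still open speak of the compounds shown alone.

Compound 2 `CCCCCCCCCO[C@@H]1[C@@H](N)[C@@H](OCC(O)CNCCCN)O[C@H](CN)[C@H]1OCCCCCCCCC` was examined in a toxicity assay on the whole organism (J774 cells) for cytotoxicity, with Mus musculus as the target, read by MTT assay, with a stated time of 24 h, tested at 10 uM (a lower number here means a stronger effect, a higher number a weaker effect of the compound at the concentration tested), where compound 2 gives 101%. Among the three compounds measured so far, this is the highest number. The nearest is compound 3 `NC[C@H]1O[C@H](O[C@H]2[C@H](O)[C@@H](OCc3ccc4ccccc4c3)[C@H](N)C[C@@H]2N)[C@H](N)[C@@H](OCc2ccc3ccccc3c2)[C@@H]1O`, which in this assay gives 86%, a gap beyond the scatter. Furthest away is compound 1 `NC[C@H]1O[C@H](O[C@H]2[C@H](O)[C@@H](O)[C@H](N)C[C@@H]2N)[C@H](N)[C@@H](OCc2ccc3ccccc3c2)[C@@H]1OCc1ccc2ccccc2c1`, which in this assay gives 79.1%, again beyond the scatter. For the measured compounds named here, no two of these three compounds differ in one place only, so no single measured step is available. Compound 4 `CCCCCCCCCO[C@@H]1[C@@H](N)[C@@H](O[C@H]2[C@H](O)[C@@H](O)[C@H](N)C[C@@H]2N)O[C@H](CN)[C@H]1OCCCCCCCCC` has not yet been measured. It differs from compound 2 as follows: 4,6-diamino-2,3-dihydroxycyclohexyl in place of 3-((3-aminopropyl)amino)-2-hydroxypropyl on an oxygen on a saturated carbon. Compounds 1 and 3 both carry the 4,6-diamino-2,3-dihydroxycyclohexyl group and both stand below compound 2 in this assay, though neither is a one-place neighbour of compound 4. On that basis the expected step is a number 11 percentage points lower from compound 2 to compound 4 (beyond the scatter), small and possibly within the scatter. Compound 4 is therefore estimated at 90% in this assay, with a range from 72% to 105%.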

Compound 4, a percentage reported as activity, at one concentration (the size of the read-out at that concentration, not a potency): 82.7%
The estimate for compound 4 lay 7.3 percentage points above the measured number; low and high end bracket the measured number.
By their numbers in this assay, from the lowest: compounds 1, 4 and 3 (each within the scatter of the next); then compound 2.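

In this assay, for the compounds shown here, the step of a number 18.3 percentage points lower from compound 2 to compound 4 (beyond the scatter) gives the first direct reading at this position: with the rest of the molecule unchanged, putting 4,6-diamino-2,3-dihydroxycyclohexyl in place of 3-((3-aminopropyl)amino)-2-hydroxypropyl on an oxygen on a saturated carbon changes the read-out by a modest amount. The group on this oxygen therefore matters in this assay, and the open chain and the six-membered non-aromatic ring are not interchangeable here. Nothing measured alongside this result accounts for the step.

The compounds shown leave open whether the step follows from the ring itself or from the particular groups it carries. A plain cyclohexyl group, a ring with a single amine, or a longer diamine chain on the same oxygen would separate these readings.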